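Amine Swap on a Shorter Chain: Expected Cell Potency

A few compounds are considered here, and "the series" means these few. Any claim that something is new, unique, unknown or untested is made for them only; others in the source may bear on it.

Compound 1 `COc1cc2oc(-c3ccccc3)cc(=O)c2c(O)c1OCCCCN1CCN(C)CC1` gives 32000 nM in a functional assay on A549 cells (Homo sapiens) for antiproliferative activity, read by MTT assay, with a stated time of 48 h; on this read-out lower numbers stand for stronger inhibition and higher numbers for weaker inhibition.
Compound 2 `CCN(CC)CCCCOc1c(OC)cc2oc(-c3ccccc3)cc(=O)c2c1O` gives 35000 nM in this assay.
Compound 3 `COc1cc2oc(-c3ccccc3)cc(=O)c2c(O)c1OCCCN1CCN(C)CC1` gives 18000 nM in this assay.

All three measured compounds share the same core and carry a basic amine at the end of a chain attached through an oxygen on the aromatic ring. Compound 4 `CCN(CC)CCCOc1c(OC)cc2oc(-c3ccccc3)cc(=O)c2c1O` has not yet been measured in this assay. It differs from compound 3 by diethylamino in place of 4-methylpiperazin-1-yl on a saturated chain carbon, three bonds along the chain from an oxygen on an aromatic ring. The same kind of change has already been measured once, from compound 1 to compound 2, where it reads (diethylamino in place of 4-methylpiperazin-1-yl on a saturated chain carbon, four bonds along the chain from an oxygen on an aromatic ring); that step was a 1.1-fold higher number from compound 1 to compound 2 (0.04 log units; within the scatter). The two places are not identical: in the measured pair the group sits four bonds along the chain from an oxygen on an aromatic ring, whereas in the new pair it sits three bonds along the chain. The two cores themselves differ by 4-methylpiperazin-1-yl in place of (4-methylpiperazin-1-yl)methyl on a saturated chain carbon, three bonds along the chain from an oxygen on an aromatic ring, and that change gave a 1.8-fold lower number from compound 1 to compound 3 (0.25 log units; within the scatter). Compound 2 and compound 3 differ by a 1.9-fold lower number from compound 2 to compound 3 (0.29 log units; within the scatter).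

Because the measured swap gave a 1.1-fold higher number from compound 1 to compound 2 (0.04 log units; within the scatter), the step from compound 3 to compound 4 is expected to be a 1.2-fold higher number from compound 3 to compound 4 (0.09 log units; within the scatter), of similar small size. This expectation rests on a single measured pair, with a chain one bond longer, so it carries real uncertainty. For compound 4 the estimate in this assay is 22000 nM, expected to lie between 10000 nM and 45000 nM.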

Compound 4, half-maximal inhibitory concentration: 4900 nM
Compound 4: the middle estimate sits 4.5-fold (0.65 log units) above what was measured; the whole stated range lies above it.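

In this assay, swapping 4-methylpiperazin-1-yl for diethylamino did not have the same effect on both cores, which here differ only in the length of the chain that carries the amine: the same change on two cores in this assay, a 1.1-fold higher number (0.04 log units; within the scatter) from compound 1 to compound 2 and a 3.7-fold lower number (0.57 log units; beyond the scatter) from compound 3 to compound 4, 4.0-fold (0.60 log units) apart, beyond the scatter of two such steps

Set together, the steps of a 3.7-fold lower number from compound 3 to compound 4 (0.57 log units; beyond the scatter), a 7.1-fold lower number from compound 2 to compound 4 (0.85 log units; beyond the scatter) and a 6.5-fold lower number from compound 1 to compound 4 (0.81 log units; beyond the scatter) all lie beyond the usual scatter, so the 3-(diethylamino)propyl chain gives the lowest number of the four molecules. Among these compounds, this shows that, in this series, the result of an amine swap measured on one chain could not simply be carried over to a chain of another length, but with only one pair for each chain it gives no general rule and does not say why the two steps differ.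

The compounds shown leave open whether other amines, such as morpholine or pyrrolidine, would follow diethylamino or 4-methylpiperazin-1-yl on these two chains. They also leave open what the same swap would do on a 2-(diethylamino)ethyl chain or on a longer chain, and so whether the low number belongs to the propyl chain alone.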